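This account rests on a few compounds, and the source may have more. Where it says the series, first, only, none or still open, it means among the compounds named here.

Among the measured compounds shown here, in a functional assay on the whole organism (strain Sprague-Dawley) for inhibition, with Rattus norvegicus as the target, with a stated time of 10 min (a higher number here means that more compound is needed for the effect, a lower number that less compound is needed), two compounds with a shared core have numbers so far. Compound 1 `O=C(O)c1cnc(-c2ccccc2Cl)[nH]c1=O` gives 5 mg/kg, and compound 2 `CC(C)Oc1ccccc1-c1ncc(C(=O)O)c(=O)[nH]1` gives 0.8 mg/kg, the lower of the two. Compound 3 `CC(C)COc1ccccc1-c1ncc(C(=O)O)c(=O)[nH]1` departs from compound 2 in a single place: isobutyl in place of isopropyl on an oxygen on an aromatic ring. Put in words, this is isobutyl in place of isopropyl on an oxygen on an aromatic ring, or isopropoxy to isobutoxy when the cut is made one bond further out.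

For the measured compounds named here, only one measured step bears on this change, and it bears only indirectly. Replacing chloro with isopropoxy gave a 6.3-fold lower number from compound 1 to compound 2 (0.80 log units; beyond the scatter), a move beyond the scatter. That step swapped one group for a different kind of group, whereas the new change only alters the alkyl part of an alkoxy group, so a much smaller step is expected. The data do not fix its direction, and no shift beyond the scatter is anticipated. The expected step is a 1.3-fold higher number from compound 2 to compound 3 (0.10 log units; within the scatter). The estimate for compound 3 is 1 mg/kg, within a range of 0.3 mg/kg to 3 mg/kg.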

Compound 3, dose for 50% inhibition: 0.5 mg/kg
The estimate for compound 3 lay 2.0-fold (0.30 log units) above the measured number, within the range that was stated.
By their numbers in this assay, from the lowest: compounds 3 and 2 (each within the scatter of the next); then compound 1.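

In this assay, isobutyl in place of isopropyl on an oxygen on an aromatic ring gives a 1.6-fold lower number from compound 2 to compound 3 (0.20 log units; within the scatter) and so leaves compound 2 and compound 3 within the scatter of each other, which means that this added carbon does not separate the two compounds in this read-out. Measured against the chloro compound, the isobutoxy group gives a 10-fold lower number from compound 1 to compound 3 (1.00 log units; beyond the scatter), so a step beyond the scatter from compound 1 is now seen with two different alkoxy groups rather than with isopropoxy alone. No measurement shown here accounts for either step.

The compounds shown leave open how far the alkyl part on this oxygen can change before the number moves beyond the scatter, as a longer chain such as n-hexyl, a cyclohexyl ring or a chain ending in an amine would test. They also leave open whether the oxygen itself matters, since a plain isobutyl group on the aromatic carbon, with no oxygen, would be needed to separate its contribution from that of the alkyl part.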